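Amide Side Chain Change and Tolerated Concentration

A few compounds are considered here, and "the series" means these few. Any claim that something is new, unique, unknown or untested is made for them only; others in the source may bear on it.

Compound 1, `COc1cc(F)ccc1CNC(=O)c1cc2nc(C)c([C@H](OC(C)(C)C)C(=O)O)c(-c3cc(F)c4c(c3C)CCCO4)n2n1`, gives > 40000 nM in an ADME assay on MT2 cells (Homo sapiens) for cytotoxicity (a higher number here means that more compound is tolerated, a lower number that less compound is tolerated), which is a limit of the assay and not a number.
Compound 2, `CCCNC(=O)c1cc2nc(C)c([C@H](OC(C)(C)C)C(=O)O)c(-c3cc(F)c4c(c3C)CCCO4)n2n1`, gives > 40000 nM in this assay, again a limit of the assay and not a number.

Compound 2 therefore stands at the upper limit of this assay, where every value shown sits, as the limit of > 40000 nM in this assay, at which 2 of the 2 values shown sit, records. Going by the values given here, the only measured step, a step that the two limits leave unreadable from compound 1 to compound 2, is a step that the two limits leave unreadable, so its size is not known.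

The next compound, compound 3, `Cc1nc2cc(C(=O)NCC3CCOCC3)nn2c(-c2cc(F)c3c(c2C)CCCO3)c1[C@H](OC(C)(C)C)C(=O)O`, differs from compound 2 by oxan-4-yl in place of ethyl on a saturated chain carbon bound to an amide-type nitrogen. The measured step bears on the same place but offers no readable size, so nothing in the numbers points to a direction for this change. Compound 3 is therefore expected to remain at the limit of this assay, with the step that the limit leaves unreadable from compound 2 to compound 3 expected to show no change beyond the usual scatter. The estimate for compound 3 is 45000 nM, with a range from 20000 nM to 100000 nM, and most likely the assay will again report only a limit.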

Compound 3, half-maximal cytotoxic concentration: > 40000 nM
Compound 3: only a limit was reported (the forecaster's own chance of this, stated with the estimate: 85%); the middle value lies beyond the limit too.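

Compound 3 gives > 40000 nM in this assay, which is a limit of the assay and not a number. Going by these compounds alone, no step among compound 1, compound 2 and compound 3 can therefore be read. The compounds shown leave open what concentration each one actually tolerates and whether the amide side chain has any bearing on it.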